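Adding a second chloro to compound 2: working notes

The source may report more compounds than this note shows. Statements on the series, on what has been measured and on what is new or still open speak of the compounds shown alone.

Three compounds of the series have numbers in a functional assay on MDA-MB-231 cells (Homo sapiens) for cytotoxicity, read by MTT assay, with a stated time of 72 h; on this read-out higher numbers stand for weaker inhibition and lower numbers for stronger inhibition. Compound 1 `CN(C)CCCNc1nc(-c2ccc(NC(=O)Nc3ccccc3F)cc2)nc2ccsc12` gives 660 nM in this assay. Compound 2 `CN(C)CCCNc1nc(-c2ccc(NC(=O)Nc3ccccc3Cl)cc2)nc2ccsc12` gives 590 nM. Compound 3 `CN(C)CCCNc1nc(-c2ccc(NC(=O)Nc3ccc(Cl)cc3)cc2)nc2c(Cl)c(Cl)sc12` differs from compound 2 in several places. In this assay compound 3 gives 1160 nM. Compound 2 has the lowest of the three numbers, but its gap to compound 1 and its gap to compound 3 both sit within the scatter, so no ordering among them is claimed.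

Among the measured compounds shown here, the one single-point step measured so far is a 1.1-fold lower number from compound 1 to compound 2 (0.05 log units; within the scatter), a chloro replacing a fluoro on an aromatic carbon, with no change beyond the scatter.

Compound 4 `CN(C)CCCNc1nc(-c2ccc(NC(=O)Nc3ccc(Cl)cc3Cl)cc2)nc2ccsc12` has not yet been measured. Relative to compound 2 the change is chloro in place of hydrogen on an aromatic carbon. For the measured compounds named here, the only measured step that bears on this change is the halogen exchange from compound 1 to compound 2, and it lies within the scatter; there is no measured step that adds a chloro to a ring that already carries one. On that basis the step of a 1.0-fold higher number from compound 2 to compound 4 (0.01 log units; within the scatter) is expected to be small, in no clear direction, and most likely within the scatter.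

Compound 4 is therefore estimated at 600 nM in this assay, with a range from 300 nM to 1300 nM.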

Compound 4, half-maximal inhibitory concentration: 1860 nM
Estimate against measurement, compound 4: 3.1-fold (0.49 log units) below; measured number outside the range, above it.
By their numbers in this assay, from the lowest: compounds 2, 1, 3 and 4 (each within the scatter of the next, the first and the last beyond it).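

In this assay, among the compounds shown here, chloro in place of hydrogen on an aromatic carbon, meta to a chloro group and para to a large group, gives a 3.2-fold higher number from compound 2 to compound 4 (0.50 log units; beyond the scatter), the first single-point step to lie beyond the scatter. Set against the 2-fluorophenyl group, the 2,4-dichlorophenyl group also goes beyond the scatter, with a 2.8-fold higher number from compound 1 to compound 4 (0.45 log units; beyond the scatter), whereas the halogen exchange a 1.1-fold lower number from compound 1 to compound 2 (0.05 log units; within the scatter) stayed within it. On this ring, the added chloro therefore moves the number towards weaker inhibition, where exchanging one halogen for another gave no change beyond the scatter.

Nothing in the available data speaks to the origin of this step. From the compounds shown here alone, it remains open whether the step is specific to chloro or would also appear with another group on the same carbon, such as a methyl group, a methoxy group or an amine, and whether a chloro on that carbon would give the same step with the shared core unchanged and no chloro on the ring already.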